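Ring-amine benzyl aryl variation: compound 3 to compound 4

The source may hold more compounds than are shown below. What is called first, only, known or untested is meant among the compounds shown, and "the series" means these compounds.

Three compounds share one core and differ only in the aryl group sitting on a saturated chain carbon bound to an amine nitrogen in a ring. In an assay on FRT cells for positive allosteric modulation of Cystic fibrosis transmembrane conductance regulator variant N1303K (Homo sapiens), in the presence of a further agent that is not named here (on this read-out higher numbers stand for an effect only at larger amounts of compound and lower numbers for an effect already at smaller amounts), compound 1 `COc1ccc2[nH]c3c(c2c1)CCNC31CCN(Cc2cc(Cl)ccc2[N+](=O)[O-])CC1` gives 7100 nM, compound 2 `COc1ccc2[nH]c3c(c2c1)CCNC31CCN(Cc2ccc(Br)cc2F)CC1` gives 1600 nM and compound 3 `COc1ccc2[nH]c3c(c2c1)CCNC31CCN(Cc2cc(F)cc(F)c2)CC1` gives 11100 nM. Compound 3 carries the highest number of the three; its gap to compound 1 stays within the scatter, whereas a 6.9-fold higher number from compound 2 to compound 3 (0.84 log units; beyond the scatter). Compound 4 `COc1ccc2[nH]c3c(c2c1)CCNC31CCN(Cc2ccc(F)c(F)c2F)CC1` carries 2,3,4-trifluorophenyl in place of 3,5-difluorophenyl on a saturated chain carbon bound to an amine nitrogen in a ring. Every measured step alters this same aryl group: a 4.4-fold lower number from compound 1 to compound 2 (0.65 log units; beyond the scatter), a 1.6-fold higher number from compound 1 to compound 3 (0.19 log units; within the scatter) and a 6.9-fold higher number from compound 2 to compound 3 (0.84 log units; beyond the scatter). The 2,3,4-trifluorophenyl entering in compound 4 resembles the 4-bromo-2-fluorophenyl of compound 2 in its substitution pattern more closely than the 3,5-difluorophenyl it replaces, and compound 2 gives 1600 nM. In this assay, for the measured compounds named here, a lowering step of about a 2.5-fold lower number from compound 3 to compound 4 (0.39 log units; beyond the scatter) is therefore expected, smaller than the gap separating compound 3 from compound 2, since no measured pair tests this exact trifluoro pattern. Compound 4 is estimated at 4500 nM, within a range from 1500 nM to 13000 nM.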

Compound 4, half-maximal effective concentration: 4100 nM
Beside the measured number, compound 4's estimate is 1.1-fold (0.04 log units) above it; low and high end bracket the measured number.
By their numbers in this assay, from the lowest: compound 2; then compounds 4, 1 and 3 (each within the scatter of the next, the first and the last beyond it).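

In this assay, the change between two aryl groups bearing only fluorine gives a 2.7-fold lower number from compound 3 to compound 4 (0.43 log units; beyond the scatter), so at this place a lower number does not require the bromine of compound 2. The 4-bromo-2-fluorophenyl group still holds the lowest number of the series, with a 2.6-fold higher number from compound 2 to compound 4 (0.41 log units; beyond the scatter), whereas a 1.7-fold lower number from compound 1 to compound 4 (0.24 log units; within the scatter) leaves the 2,3,4-trifluorophenyl and 5-chloro-2-nitrophenyl groups within the scatter of each other. Nothing on hand explains these steps.

As far as these compounds go, the step to 2,3,4-trifluorophenyl changes both the number of fluorines and their pattern, so the share of each stays open. Also open, from the compounds shown here alone, is how a pyridylmethyl group in place of the benzyl, or a methoxy or nitrile on the aryl ring, would read at this place.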